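The source may report more compounds than this note shows. Statements on the series, on what has been measured and on what is new or still open speak of the compounds shown alone.

In a functional assay on MDA-MB-231 cells (Homo sapiens) for antiproliferative activity, read by CCK-8 assay, with a stated time of 72 h (a lower number here means a stronger inhibitor, a higher number a weaker inhibitor), compound 3 `CC1=NN(c2ccc(Cl)cc2)C(=O)C12C=CC(=O)C=C2c1cccc(C)c1` gives 26900 nM, the lowest of the two numbers shown. Compound 2 `CC1=NN(c2ccccc2)C(=O)C12C=CC(=O)C=C2c1cccc(C)c1` gives 85800 nM, and the step of a 3.2-fold lower number from compound 2 to compound 3 (0.50 log units; beyond the scatter) comes from chloro in place of hydrogen on an aromatic carbon. Compound 1 `CC1=NN(c2ccc(Br)cc2)C(=O)C12C=CC(=O)C=C2c1ccccc1` gives > 100000 nM, which is a limit of this assay and not a number, as noted in the limit of > 100000 nM in this assay, at which 1 of the 3 values shown sits.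

Compound 4 `CC1=NN(c2ccc(Br)cc2)C(=O)C12C=CC(=O)C=C2c1cccc(C)c1` differs from compound 3 by bromo in place of chloro on an aromatic carbon. Going by the values given here, no measured step exchanges chloro for bromo; the only measured step, a 3.2-fold lower number from compound 2 to compound 3 (0.50 log units; beyond the scatter), concerns adding a halogen where none was, so it offers little guidance here. The expected step of a 1.1-fold lower number from compound 3 to compound 4 (0.03 log units; within the scatter) is therefore small, within the scatter. Compound 4 is estimated at 25000 nM, with a range from 8000 nM to 80000 nM.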

Compound 4, half-maximal inhibitory concentration: 2890 nM
Estimate against measurement, compound 4: 8.7-fold (0.94 log units) above; the whole stated range lies above it.
By their numbers in this assay, from the lowest: compound 4; then compound 3; then compound 2. At a limit, above all of these: compound 1.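

Which halogen sits at this place matters, not only whether one is present: going from 4-chlorophenyl to 4-bromophenyl gives a 9.3-fold lower number from compound 3 to compound 4 (0.97 log units; beyond the scatter), and bromo in place of hydrogen gives a 30-fold lower number from compound 2 to compound 4 (1.47 log units; beyond the scatter). With bromo in place, the methyl that separates the two compounds also counts, giving an at least 34-fold lower number from compound 1 to compound 4 (1.53 log units; beyond the scatter). That step starts from compound 1, whose value is a limit and not a number: the limit of > 100000 nM in this assay, at which 1 of the 4 values shown sits.

Going by these compounds, whether iodo, methoxy or an amine at this same place would lower the number further stays open. So does the effect of a longer chain in place of the methyl.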